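The source may report more compounds than this note shows. Statements on the series, on what has been measured and on what is new or still open speak of the compounds shown alone.

Three compounds were measured in a functional assay on K562 cells (Homo sapiens) for cytotoxicity, read by MTT assay, with a stated time of 72 h; a higher number here means a weaker inhibitor, a lower number a stronger inhibitor:

compound 1 `CCCOCNc1n[n+]([O-])c2cc(OC)ccc2[n+]1[O-]`: 4280 nM
compound 2 `[O-][n+]1nc(NCOC2CCCCC2)[n+]([O-])c2ccccc21`: 10800 nM
compound 3 `COCNc1n[n+]([O-])c2ccccc2[n+]1[O-]`: 7800 nM

Of these three numbers, that of compound 1 is the lowest; its gap to compound 3 is within the scatter, while its gap to compound 2 is beyond it. Compound 4 `COc1ccc2c(c1)[n+]([O-])nc(NCOCc1ccccc1)[n+]2[O-]` has not yet been measured. It differs from compound 1 in one place: phenyl in place of ethyl on a saturated chain carbon bound to an oxygen on a saturated carbon. For the measured compounds named here, the only measured step that touches the same side chain is a 1.4-fold lower number from compound 2 to compound 3 (0.14 log units; within the scatter), a swap of ring for chain on the far side of the same oxygen, and it stayed within the scatter. Going by the values given here, no measured step swaps phenyl for ethyl on the carbon itself, so the expectation for compound 4 rests on that one step alone, and no step beyond the scatter is expected in this assay. Compound 4 is therefore estimated at 4500 nM, within 2000 nM to 10000 nM, which means an expected step of a 1.1-fold higher number from compound 1 to compound 4 (0.02 log units; within the scatter).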

Compound 4, half-maximal inhibitory concentration: 27500 nM
Compound 4: the middle estimate sits 6.1-fold (0.79 log units) below what was measured; measured number outside the range, above it.
By their numbers in this assay, from the lowest: compounds 1, 3 and 2 (each within the scatter of the next, the first and the last beyond it); then compound 4.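

In this assay this side chain proved able to shift the number beyond the scatter: phenyl in place of ethyl on a saturated chain carbon bound to an oxygen on a saturated carbon gave a 6.4-fold higher number from compound 1 to compound 4 (0.81 log units; beyond the scatter) and so a clearly weaker compound. The earlier change on the far side of the same oxygen, a 1.4-fold lower number from compound 2 to compound 3 (0.14 log units; within the scatter) on the core without the methoxy group, had not shown that this part of the molecule can matter. No evidence is available on the cause of the new step.

The compounds shown leave open whether the loss follows the aromatic ring or simply the larger group, which a cyclohexylmethyl group on that oxygen would help to separate. They also leave open whether a longer chain such as butyl keeps the number of compound 1 or already moves it.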